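Replacing the cyclohexyl group of compound 2

The source may report more compounds than this note shows. Statements on the series, on what has been measured and on what is new or still open speak of the compounds shown alone.

In a functional assay on HepG2 cells (Homo sapiens) for inhibition, read by scintillation counting, with a stated time of 2 h (on this read-out higher numbers stand for weaker inhibition and lower numbers for stronger inhibition), compound 1 `CCNC(=O)Nc1sc2ccccc2c1C(=O)N1CCN(C2CCN(C(=O)C3CCCCC3)CC2)CC1` gives 146 nM and compound 2 `CCNC(=O)Nc1sc2ccccc2c1C(=O)N1CCN(C2CCN(C(=O)OC3CCCCC3)CC2)CC1` gives 635 nM as the higher number of the two, which means the weaker inhibition. Among the measured compounds shown here, the one measured step is a 4.3-fold higher number from compound 1 to compound 2 (0.64 log units; beyond the scatter) for cyclohexyloxy in place of cyclohexyl on a carbonyl carbon, modest in size. Compound 3 `CCNC(=O)Nc1sc2ccccc2c1C(=O)N1CCN(C2CCN(C(=O)OC(C)(C)CF)CC2)CC1` has 1-(fluoromethyl)-1-methylethyl in place of cyclohexyl on an oxygen next to a carbonyl group, so only what that oxygen carries changes. For the measured compounds named here, no measured step covers this swap, so compound 2 at 635 nM is the starting point, and a 4.3-fold higher number from compound 1 to compound 2 (0.64 log units; beyond the scatter) gives only a rough sense of size and no direction. In this assay the expected change is a 1.1-fold lower number from compound 2 to compound 3 (0.02 log units; within the scatter) and no step beyond the scatter is expected. The estimate for compound 3 is 600 nM with 180 nM to 2000 nM as the expected range.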

Compound 3, half-maximal inhibitory concentration: 61 nM
Beside the measured number, compound 3's estimate is 9.8-fold (0.99 log units) above it, outside the stated range (below it).
By their numbers in this assay, from the lowest: compound 3; then compound 1; then compound 2.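

In this assay what the oxygen next to a carbonyl group carries matters strongly: 1-(fluoromethyl)-1-methylethyl in place of cyclohexyl gives a 10-fold lower number from compound 2 to compound 3 (1.02 log units; beyond the scatter) and so much stronger inhibition, which shows that a six-membered ring is not needed at this place. The comparison with compound 1 gives a 2.4-fold lower number from compound 1 to compound 3 (0.38 log units; beyond the scatter) and makes compound 3 the strongest inhibitor of the three. Nothing available explains why this swap has so large an effect.

The swap removes the ring and brings in a fluorine at the same time, so the compounds shown cannot tell which of the two changes matters. A tert-butyl group on this oxygen, which keeps the branching but has no fluorine, would help to separate them.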